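Swapping the aryl group on a cytotoxic bis-arylidene piperidinone

This account rests on a few compounds, and the source may have more. Where it says the series, first, only, none or still open, it means among the compounds named here.

Compound 1, `COc1cc(/C=C2\CN(C)C/C(=C\c3ccc(Cl)c(Cl)c3)C2=O)cc(OC)c1`, is the reference point of this small set. In a functional assay on HepG2 cells (Homo sapiens) for cytotoxicity, read by MTT assay, with a stated time of 24 h (on this read-out lower numbers stand for stronger inhibition and higher numbers for weaker inhibition), compound 1 gives 3840 nM. Compound 2, `COc1cc(/C=C2\CN(C)C/C(=C\c3cccc([N+](=O)[O-])c3)C2=O)cc(OC)c1`, carries the change (3-nitrophenyl in place of 3,4-dichlorophenyl on a double-bonded chain carbon bound to a double-bonded ring carbon), and in this assay compound 2 gives 1840 nM, which is a 2.1-fold lower number from compound 1 to compound 2 (0.32 log units; beyond the scatter).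

Compound 3, `COc1cc(/C=C2\CN(C)C/C(=C\c3ccc(Cl)c(Cl)c3)C2=O)cc(OC)c1OC`, differs from compound 1 by methoxy in place of hydrogen on an aromatic carbon; this is the only difference between the two cores. In this assay compound 3 gives 6960 nM, a change described as a 1.8-fold higher number from compound 1 to compound 3 (0.26 log units; within the scatter). The gap between compound 3 and compound 2 is larger and lies beyond the scatter.

Compound 4, `COc1cc(/C=C2\CN(C)C/C(=C\c3cccc([N+](=O)[O-])c3)C2=O)cc(OC)c1OC`, has not yet been measured. It differs from compound 3 by 3-nitrophenyl in place of 3,4-dichlorophenyl on a double-bonded chain carbon bound to a double-bonded ring carbon. This is the same change already seen between compound 1 and compound 2, at the same place, so the pair compound 3 to compound 4 is the second occurrence of it among these compounds. Since the earlier occurrence gave a 2.1-fold lower number from compound 1 to compound 2 (0.32 log units; beyond the scatter), and since the cores of compound 1 and compound 3 differ only by methoxy in place of hydrogen on an aromatic carbon, the step from compound 3 to compound 4 is expected to be similar, namely a 2.1-fold lower number from compound 3 to compound 4 (0.32 log units; beyond the scatter). That expectation rests on one prior pair alone and on the value of compound 3, 6960 nM.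

On that basis compound 4 is estimated at 3300 nM in this assay, with a likely range from 1700 nM to 6500 nM.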

Compound 4, half-maximal inhibitory concentration: 1890 nM
Compound 4: middle estimate off by 1.7-fold (0.24 log units), on the high side, and the stated range covers the measured number.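

In this assay, among these compounds, the swap of 3,4-dichlorophenyl for 3-nitrophenyl on the second core gives a 3.7-fold lower number from compound 3 to compound 4 (0.57 log units; beyond the scatter), so the number falls on both cores, and the two steps do not differ by more than the usual scatter: the same change on two cores in this assay, a 2.1-fold lower number (0.32 log units; beyond the scatter) from compound 1 to compound 2 and a 3.7-fold lower number (0.57 log units; beyond the scatter) from compound 3 to compound 4, 1.8-fold (0.25 log units) apart, within the scatter of two such steps The added methoxy on an aromatic carbon, read on the 3-nitrophenyl compounds, gives a 1.0-fold higher number from compound 2 to compound 4 (0.01 log units; within the scatter), and it also carries over without a difference beyond the scatter: the same change on two cores in this assay, a 1.8-fold higher number (0.26 log units; within the scatter) from compound 1 to compound 3 and a 1.0-fold higher number (0.01 log units; within the scatter) from compound 2 to compound 4, 1.8-fold (0.25 log units) apart, within the scatter of two such steps This shows that each change behaved consistently across these four compounds, but with only two occurrences of each change, on two cores and in one assay, it does not fix the size of either step or show that the steps would transfer to other cores.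

The compounds shown leave open whether the same behaviour would hold for other groups at this place, such as an aminophenyl or a carboxyphenyl, or for a hydroxy group in place of the added methoxy. They also leave open whether these steps would appear in any read-out other than this assay.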